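The compounds below may be only part of what the source reports. "The series", "measured", "known", "first", "only" and "open" are said of these compounds alone.

Measured in a functional assay on T-24 cells (Homo sapiens) for antiproliferative activity, read by MTT assay, with a stated time of 48 h; on this read-out higher numbers stand for weaker inhibition and lower numbers for stronger inhibition:
- compound 1 `CCOc1ccc(NC(=O)Nc2cccc(CNc3nccnc3Cl)c2)cc1`: 9080 nM
- compound 2 `O=C(Nc1ccc(Cl)cc1)Nc1cccc(CNc2nccnc2Cl)c1`: 5470 nM

Going by the values given here, compound 2 stands at 5470 nM, level with compound 1 within the scatter: the only measured step is a 1.7-fold lower number from compound 1 to compound 2 (0.22 log units; within the scatter). The next compound, compound 3 `O=C(Nc1cccc(CNc2nccnc2Cl)c1)NC1CCCC1`, differs from compound 2 as follows: cyclopentyl in place of 4-chlorophenyl on an amide-type nitrogen. In words, this is cyclopentyl in place of 4-chlorophenyl on an amide-type nitrogen.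

The measured step bears on this change only weakly. It swaps ethoxy for chloro on an aromatic carbon and keeps the aromatic ring, whereas compound 3 loses that ring altogether. Among the compounds with values here, no measured compound shows what such a loss does, so the direction rests on little. Compound 1 and compound 2 both carry the aromatic ring and differ only by a 1.7-fold lower number from compound 1 to compound 2 (0.22 log units; within the scatter), so the data give no sign of a gain from leaving it. A modest move towards weaker inhibition in this assay is expected, with no firm size. The estimated step is a 1.8-fold higher number from compound 2 to compound 3 (0.26 log units; within the scatter). For compound 3 the expected value is 10000 nM, with an estimated range of 3500 nM to 30000 nM.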

Compound 3, half-maximal inhibitory concentration: > 40000 nM
Compound 3: no number, only a limit (the forecaster's own chance of this, stated with the estimate: 15%); at least 4.0-fold (0.60 log units) between middle value and limit.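

For compound 3 the entry in this assay is a limit and not a number: the limit of > 40000 nM in this assay, at which 1 of the 3 values shown sits. At the amide-type nitrogen, the group can no longer be treated as interchangeable: cyclopentyl in place of 4-chlorophenyl gives an at least 7.3-fold higher number from compound 2 to compound 3 (0.86 log units; beyond the scatter), and cyclopentyl in place of 4-ethoxyphenyl gives an at least 4.4-fold higher number from compound 1 to compound 3 (0.64 log units; beyond the scatter). The earlier pair kept the aromatic ring and changed only its ethoxy or chloro group, with a step that stayed within the scatter, whereas both new steps, which replace the aromatic ring with a five-membered non-aromatic ring, lie beyond the scatter and point towards weaker inhibition.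

The compounds shown do not separate the loss of the aromatic ring from the particular choice of cyclopentyl, and an unsubstituted phenyl, a cyclohexyl or a benzyl group on the same nitrogen would bear on that question. Also open, going by these compounds, is how far the ring substituent can be varied while the aromatic ring stays in place, for instance with a dimethylamino group or a carboxylic acid in place of chloro.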